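Trifluoromethyl in Place of Fluoro on the Aryl Ring

The compounds below may be only part of what the source reports. "The series", "measured", "known", "first", "only" and "open" are said of these compounds alone.

Measured compounds:
compound 1 `C=C(C)C(=O)c1ccc(OCc2nc(-c3ccc(C(F)(F)F)cc3)no2)cc1Br` — 1300 nM
compound 2 `C=C(C)C(=O)c1ccc(OCc2nc(-c3ccc(F)cc3)no2)cc1C` — 3500 nM

Of the compounds shown here, two have been measured in an assay on HL-60 cells for inhibition of glutathione S-transferase P (Homo sapiens); a higher number here means a weaker inhibitor, a lower number a stronger inhibitor. Compound 1 gives 1300 nM in this assay, and compound 2 gives 3500 nM. Compound 2 therefore stands with the higher of the two numbers, and its distance from compound 1 lies beyond the usual scatter of repeated measurements. Compound 1 and compound 2 differ in two places at once, so their gap cannot be assigned to either change alone.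

Compound 3 `C=C(C)C(=O)c1ccc(OCc2nc(-c3ccc(C(F)(F)F)cc3)no2)cc1C` has not been measured. It differs from compound 2 in one place: trifluoromethyl in place of fluoro on an aromatic carbon. The rest of the shared core, including the methyl group beside the ketone-bearing ring, is kept from compound 2.

There is no directly measured step of this kind in the series. Compound 3 carries the same trifluoromethyl-bearing aryl group as compound 1, whose value of 1300 nM is lower than that of compound 2, and this is the only hint at the direction. A modest move toward a lower number is expected for the step from compound 2 to compound 3, a 1.8-fold lower number from compound 2 to compound 3 (0.24 log units; within the scatter), though it may stay within the scatter. Compound 3 is thus estimated at 2000 nM in this assay, with a range from 800 nM to 5000 nM.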

Compound 3, half-maximal inhibitory concentration: 3300 nM
Compound 3: middle estimate off by 1.7-fold (0.22 log units), on the low side; the range from low to high includes it.
By their numbers in this assay, from the lowest: compound 1; then compounds 3 and 2 (each within the scatter of the next).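

In this assay, trifluoromethyl in place of fluoro on an aromatic carbon, para to a large group, gives a 1.1-fold lower number from compound 2 to compound 3 (0.03 log units; within the scatter) with the methyl group held constant, so this exchange has no readable effect in this setting, despite the larger group that enters. With trifluoromethyl held constant, methyl in place of bromo on an aromatic carbon gives a 2.5-fold higher number from compound 1 to compound 3 (0.40 log units; beyond the scatter), a modest step and the only one of the two that can be read as a change. Of the two places that separate compound 1 from compound 2, the earlier values could not show which one carried the gap, and these steps now point to the bromo and methyl place rather than the fluoro and trifluoromethyl place; no accompanying measurement offers an explanation for either step.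

The compounds shown leave open whether the exchange of fluoro for trifluoromethyl would stay equally flat with bromo in place of methyl, as only a matched pair carrying bromo could tell. They also leave open how chloro or a nitrile would compare with bromo and methyl at that aromatic carbon.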